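A few compounds are considered here, and "the series" means these few. Any claim that something is new, unique, unknown or untested is made for them only; others in the source may bear on it.

In a functional assay on NCI-H1975 cells (Homo sapiens) for antiproliferative activity (on this read-out higher numbers stand for weaker inhibition and lower numbers for stronger inhibition), compound 1 `Cc1c2c(n3c1CCNC[C@@H](C)[C@H](C)Nc1cc-3ccc1C(N)=O)CC(C)(C)CC2=O` gives 27 nM and compound 2 `COCCC(=O)N1CCCc2c(C)c3c(n2-c2ccc(C(N)=O)c(c2)N[C@@H](C)[C@@H]1C)CC(C)(C)CC3=O` gives 37 nM and these two numbers lie within the usual scatter of each other. Compound 3 `Cc1c2c(n3c1CCN(C(=O)C(C)(C)N)C[C@@H](C)[C@H](C)Nc1cc-3ccc1C(N)=O)CC(C)(C)CC2=O` has (1-amino-1-methylethyl)carbonyl in place of hydrogen on an amine nitrogen in a ring of compound 1 ((1-amino-1-methylethyl)carbonyl in place of hydrogen on an amine nitrogen in a ring). For the measured compounds named here, no measured pair isolates this change, so no step beyond the scatter is expected in this assay and no direction is favoured. The expected change is a 1.1-fold higher number from compound 1 to compound 3 (0.05 log units; within the scatter) and stays within that scatter. For compound 3 the estimated value is 30 nM with an expected range from 10 nM to 90 nM in this measurement.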

Compound 3, half-maximal inhibitory concentration: 21 nM
Beside the measured number, compound 3's estimate is 1.4-fold (0.15 log units) above it, within the range that was stated.
By their numbers in this assay, from the lowest: compounds 3, 1 and 2 (each within the scatter of the next).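

Compound 1's ring amine nitrogen tolerates far more than a hydrogen in this assay: placing (1-amino-1-methylethyl)carbonyl, with its 6 heavy atoms, there gives a 1.3-fold lower number from compound 1 to compound 3 (0.11 log units; within the scatter) and so stays within the scatter. The hydrogen on this nitrogen is therefore not needed to keep the number at this level in this assay. No available evidence explains this result.
From the compounds shown here alone, it remains open whether the amino group of the new substituent matters, which a plain acetyl group on the same nitrogen could test. A carboxylic acid or a longer chain at this position also remains untested in the compounds shown here.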